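Piperidine nitrogen substituent in place of the carbonyl group

The source may hold more compounds than are shown below. What is called first, only, known or untested is meant among the compounds shown, and "the series" means these compounds.

Compound 1 `C[C@@H](CF)OC(=O)N1CCC(O[C@H]2CC[C@H](Oc3cnc(S(C)(=O)=O)cn3)CC2)CC1` and compound 2 `CS(=O)(=O)c1cnc(O[C@H]2CC[C@H](OC3CCN(C(=O)Oc4ccccc4)CC3)CC2)cn1` share the same core and differ only at the group on an oxygen next to a carbonyl group. In a functional assay on isolated protein for agonist activity at Glucose-dependent insulinotropic receptor (Homo sapiens), read by HTRF and cAMP accumulation (on this read-out higher numbers stand for an effect only at larger amounts of compound and lower numbers for an effect already at smaller amounts), compound 1 gives 31.1 nM and compound 2 gives 9.6 nM, the lowest of the two numbers, separated by the step of a 3.2-fold lower number from compound 1 to compound 2 (0.51 log units; beyond the scatter). Compound 3 `CS(=O)(=O)c1cnc(O[C@H]2CC[C@H](OC3CCN(CC4(C(F)(F)F)CC4)CC3)CC2)cn1` carries (1-(trifluoromethyl)cyclopropyl)methyl in place of phenoxycarbonyl on an amine nitrogen in a ring. Among the measured compounds shown here, no measured step touches that ring nitrogen, so the single known step only sets a scale for a modest shift. A small loss of potency is expected, a 2.6-fold higher number from compound 2 to compound 3 (0.42 log units; beyond the scatter). Compound 3 is estimated at 25 nM, within 5 nM to 150 nM.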

Compound 3, half-maximal effective concentration: 62.6 nM
For compound 3 the middle estimate is 2.5-fold (0.40 log units) below the measured one; the range from low to high includes it.
By their numbers in this assay, from the lowest: compound 2; then compounds 1 and 3 (each within the scatter of the next).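

The ring nitrogen does not need a carbonyl group for activity. In this assay, (1-(trifluoromethyl)cyclopropyl)methyl in place of phenoxycarbonyl still gives a measurable effect, at a clear cost (a 6.5-fold higher number from compound 2 to compound 3 (0.81 log units; beyond the scatter)). Set against the non-aromatic carbonyl-bearing group of compound 1, the same replacement stays inside the usual spread (a 2.0-fold higher number from compound 1 to compound 3 (0.30 log units; within the scatter)), so the cost appears only against the phenyl-bearing compound 2. Nothing available explains either step. Open, going by these compounds, is how a benzyl group on that nitrogen would read, which would test an aromatic ring there without the carbonyl group.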